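Amino to thiophen-2-yl at the carbonyl: expected potency

The source may report more compounds than this note shows. Statements on the series, on what has been measured and on what is new or still open speak of the compounds shown alone.

Compound 1 `Nc1[nH]c(C(=O)c2ccccc2)c(-c2ccc(Cl)cc2Cl)c1C(=O)c1ccc(Cl)cc1`: in an assay for inhibition of Polyunsaturated fatty acid lipoxygenase ALOX15 (Homo sapiens), with a stated time of 10 min (on this read-out lower numbers stand for stronger inhibition and higher numbers for weaker inhibition), compound 1 gives > 100000 nM, which is a limit of the assay and not a number.
Compound 2 `NC(=O)c1c(N)[nH]c(C(=O)c2ccccc2)c1-c1ccc(Cl)cc1Cl`: in this assay compound 2 gives > 100000 nM, again a limit of the assay and not a number.

Compound 2 therefore stands at the limit of this assay; no numerical potency is known for it. Among the measured compounds shown here, the one measured step that touches the carbonyl carbon in question, a step that the two limits leave unreadable from compound 1 to compound 2, cannot be read in size or direction because of the limit of > 100000 nM in this assay, at which 2 of the 2 values shown sit.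

Compound 3 `Nc1[nH]c(C(=O)c2ccccc2)c(-c2ccc(Cl)cc2Cl)c1C(=O)c1cccs1` differs from compound 2 in one place: thiophen-2-yl in place of amino on a carbonyl carbon. For the measured compounds named here, the only measured step bearing on a change at this carbonyl carbon is the unreadable one from the limit to the limit, so neither a size nor a direction can be taken from the measured compounds for a move to thiophen-2-yl. With both measured compounds at the limit, compound 3 is expected most likely to remain there as well. Compound 3 is estimated at 150000 nM, with a range of 30000 nM to 1000000 nM. For compound 3 the expected step is a step that the limit leaves unreadable from compound 2 to compound 3.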

Compound 3, half-maximal inhibitory concentration: > 100000 nM
Compound 3: only a limit was reported; the forecaster's own chance of this, stated with the estimate: 85%; the middle value does not contradict the limit.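

No step among compound 1, compound 2 and compound 3 can be read in size or direction in this assay, because each of their values is a limit of the assay and not a number: the limit of > 100000 nM in this assay, at which 3 of the 3 values shown sit.

The compounds shown leave open whether any group on this carbonyl carbon gives a measurable inhibition.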